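Swapping the Amine-Bearing Side Chain on the Shared Core

The source may report more compounds than this note shows. Statements on the series, on what has been measured and on what is new or still open speak of the compounds shown alone.

Of the compounds shown here, three sharing one core have been measured in an assay on HeLa cells for inhibition of sphingosine-1-phosphate transporter SPNS2 (Mus musculus), read by LC-MS, tested at 2 uM; on this read-out higher numbers stand for more inhibition at the one concentration tested (going by the name of the read-out) and lower numbers for less inhibition. Compound 1 `CCCCCCCCCCc1ccc(-c2noc([C@@H]3CCC[C@@H](N)C3)n2)cc1` gives 13% in this assay. Compound 2 `CCCCCCCCCCc1ccc(-c2noc(-c3cccc(CN)c3)n2)cc1` gives 2% in this assay. Compound 3 `CCCCCCCCCCc1ccc(-c2noc([C@H](CCCCN)NC(C)=O)n2)cc1` gives 40% in this assay, the highest of the three numbers: it stands a number 27 percentage points higher from compound 1 to compound 3 (beyond the scatter) and a number 38 percentage points higher from compound 2 to compound 3 (beyond the scatter). Compound 4 `CCCCCCCCCCc1ccc(-c2noc(CCCN3CCCC3)n2)cc1` has not been measured yet. It differs from compound 3 in one place: 3-(pyrrolidin-1-yl)propyl in place of 1-acetamido-5-aminopentyl on an aromatic carbon. The two steps that end at compound 3 bear on this change; each of them also replaces the group on that same aromatic carbon, and both were beyond the scatter, one modest and one large. Within these three compounds, every other group at that position gave a lower number than the 1-acetamido-5-aminopentyl chain, so for compound 4 a drop beyond the scatter is expected, of roughly a number 22 percentage points lower from compound 3 to compound 4 (beyond the scatter). In this assay compound 4 is therefore estimated at 18%, within a range from 3% to 40%.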

Compound 4, a percentage reported as inhibition, at one concentration (the size of the read-out at that concentration, not a potency): 3%
Estimate against measurement, compound 4: 15 percentage points above, within the range that was stated.
By their numbers in this assay, from the lowest: compounds 2, 4 and 1 (each within the scatter of the next, the first and the last beyond it); then compound 3.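

In this assay, the 3-(pyrrolidin-1-yl)propyl chain does not keep the level of the 1-acetamido-5-aminopentyl chain (a number 37 percentage points lower from compound 3 to compound 4 (beyond the scatter)), so a flexible chain on this aromatic carbon is not enough on its own to give the highest number seen here. The new group also falls level with the two groups that have a ring joined straight to the core, with both a number 1 percentage points higher from compound 2 to compound 4 (within the scatter) and a number 10 percentage points lower from compound 1 to compound 4 (within the scatter) lying inside the usual variation, so among these four compounds only compound 3 stands apart. No evidence is available on what lies behind this drop.

The change swaps the whole group at once, so the acetamido group and the end amine cannot be judged separately. A plain 5-aminopentyl chain or a 3-aminopropyl chain on the shared core would help to separate them.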